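Methyl on the hydroxy oxygen of compound 2

A few compounds are considered here, and "the series" means these few. Any claim that something is new, unique, unknown or untested is made for them only; others in the source may bear on it.

Compound 1 `CC(=O)Nc1nc2ccccn2c1-c1ccc(O)cc1` was tested in an assay on isolated protein for inhibition of ubiquitin carboxyl-terminal hydrolase 47 (Homo sapiens); a higher number here means a weaker inhibitor, a lower number a stronger inhibitor. In this assay compound 1 gives only a limit, > 100000 nM. Compound 2 `Nc1nc2ccccn2c1-c1ccc(O)cc1` in this assay likewise gives only a limit, > 100000 nM. Compound 3 `CNc1nc2ccccn2c1-c1ccc(O)cc1` in this assay also gives only a limit, > 100000 nM. The steps between them can therefore not be read: a step that the two limits leave unreadable from compound 1 to compound 2, a step that the two limits leave unreadable from compound 1 to compound 3 and a step that the two limits leave unreadable from compound 2 to compound 3. All three values sit at the limit of > 100000 nM in this assay, at which 3 of the 3 values shown sit.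

Compound 4 `COc1ccc(-c2c(N)nc3ccccn23)cc1` has not been measured. It differs from compound 2 by methyl in place of hydrogen on an oxygen on an aromatic ring; cut one bond further out, hydroxy becomes methoxy. Going by the values given here, none of the measured steps touches the oxygen; the three known steps concern the nitrogen on the aromatic ring, and none of them could be read. Compound 2 stands at the limit. Changes at the nitrogen left compounds 1 and 3 at the limit as well. The chemist therefore expects the step of a number no higher from compound 2 to compound 4 (the limit leaves the size open) to be none beyond the scatter, with compound 4 most likely again reported only as a limit. His estimate for compound 4 in this assay is 100000 nM, between 30000 nM and 300000 nM.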

Compound 4, half-maximal inhibitory concentration: > 100000 nM
Compound 4 was reported as a limit (the forecaster's own chance of this, stated with the estimate: 85%); the middle value sits exactly at the limit.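

Compound 4, like compound 2, gives only a limit in this assay, so the step between them cannot be read: the limit of > 100000 nM in this assay, at which 4 of the 4 values shown sit.

The compounds shown leave open what their true values are, and whether any change at the oxygen or nitrogen would give a value that is not a limit.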